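A few compounds are considered here, and "the series" means these few. Any claim that something is new, unique, unknown or untested is made for them only; others in the source may bear on it.

Measured compounds, with values in a functional assay on DU-145 cells (Homo sapiens) for antiproliferative activity, read by propidium iodide staining, with a stated time of 96 h; a higher number here means a weaker inhibitor, a lower number a stronger inhibitor:

compound 1, `CC(O)(CSc1ccc(S(F)(F)(F)(F)F)cc1)C(=O)Nc1ccc(S(F)(F)(F)(F)F)cc1`, 22300 nM
compound 2, `CC(O)(CSc1ccc(F)cc1)C(=O)Nc1ccc(S(F)(F)(F)(F)F)cc1`, 25400 nM
compound 3, `CC(O)(CS(=O)(=O)c1ccc(S(F)(F)(F)(F)F)cc1)C(=O)Nc1cccc(S(F)(F)(F)(F)F)c1`, 17400 nM

Compound 1 and compound 2 share a core and differ in one place: one fluorine atom in place of a group of 6 heavy atoms (5 fluorine, 1 sulfur; no ring), on an aromatic carbon. In this assay this change gave a 1.1-fold higher number from compound 1 to compound 2 (0.06 log units; within the scatter), so the two numbers are not distinguished by the measurement.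

Compound 3 carries a different core. How the core of compound 1 and the core of compound 3 differ is not broken down here. Within the three measured compounds, compound 3 sits with the lowest number, but its distance to compound 1 and to compound 2 is within the usual scatter, so no ordering among the three is claimed.

Compound 4, `CC(O)(CS(=O)(=O)c1ccc(F)cc1)C(=O)Nc1cccc(S(F)(F)(F)(F)F)c1`, is not yet measured. It differs from compound 3 by one fluorine atom in place of a group of 6 heavy atoms (5 fluorine, 1 sulfur; no ring), on an aromatic carbon. The place line for this change reads the same as the place line for the change from compound 1 to compound 2, so it is the same change made on the other core.

The expectation for compound 4 rests on one precedent: the step from compound 1 to compound 2 in this assay, which was a 1.1-fold higher number from compound 1 to compound 2 (0.06 log units; within the scatter). On that basis the step from compound 3 to compound 4 in this assay is expected to be a 1.1-fold higher number from compound 3 to compound 4 (0.06 log units; within the scatter). Compound 4 is therefore estimated at 20000 nM in this assay, with a range from 9000 nM to 45000 nM. Whether the change behaves alike on the core of compound 3 is not settled by one observation on another core.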

Compound 4, half-maximal inhibitory concentration: 48800 nM
Estimate against measurement, compound 4: 2.4-fold (0.39 log units) below; measured number above the stated range.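

In this assay, putting fluoro in place of the group of 6 heavy atoms (5 fluorine, 1 sulfur) on the second core gave a 2.8-fold higher number from compound 3 to compound 4 (0.45 log units; beyond the scatter), a modest step that lies beyond the scatter, whereas the earlier step on the first core lies within it. Even so, the two steps cannot be told apart, so the measurements give no evidence that the core changes the effect of this swap: the same change on two cores in this assay, a 1.1-fold higher number (0.06 log units; within the scatter) from compound 1 to compound 2 and a 2.8-fold higher number (0.45 log units; beyond the scatter) from compound 3 to compound 4, 2.5-fold (0.39 log units) apart, within the scatter of two such steps. For the compounds shown here, this does not show that the change carries over unaltered, since each core contributes only a single pair, and two steps this far apart are compatible both with one shared effect and with a modest dependence on the core.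

Still open, from the compounds shown here alone, is how a trifluoromethyl group, a nitrile or an amine would read in the same place on either core, and whether the step would hold with one of these groups as the starting point. Also open, going by these compounds, is how the step behaves on cores beyond these two, and which of the structural differences between the core of compound 1 and the core of compound 3 matters, if any does.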